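Amide variation on the shared chloro-triazolopyridine core

A few compounds are considered here, and "the series" means these few. Any claim that something is new, unique, unknown or untested is made for them only; others in the source may bear on it.

Measured compounds:
Compound 1 `O=C(Nc1ccc(Cl)c(-c2nnc3c(Cl)cccn23)c1)c1ccc(Cl)cc1`: in a functional assay on MDA-MB-468 cells (Homo sapiens) for antiproliferative activity, read by MTT assay, with a stated time of 72 h (a higher number here means a weaker inhibitor, a lower number a stronger inhibitor), compound 1 gives > 100000 nM, which is a limit of the assay and not a number.
Compound 2 `O=C(Nc1ccc(Cl)c(-c2nnc3c(Cl)cccn23)c1)c1ccon1`: in this assay compound 2 gives > 100000 nM, again a limit.
Compound 3 `O=C(Nc1ccc(Cl)c(-c2nnc3c(Cl)cccn23)c1)c1ccc(C(F)(F)F)cc1Cl`: in this assay compound 3 gives > 100000 nM, also a limit.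

Compound 2 thus stands at the limit of this assay together with the other two values shown; nothing distinguishes it on the numbers. Going by the values given here, the single step among the measured compounds, a step that the two limits leave unreadable from compound 1 to compound 2, runs between two limits and its size cannot be read. Among the compounds with values here, the only evidence on the series is the limit of > 100000 nM in this assay, at which 3 of the 3 values shown sit: every value shown sits at the limit.

Compound 4 `O=C(Nc1ccc(Cl)c(-c2nnc3c(Cl)cccn23)c1)c1cccnc1` differs from compound 2 as follows: pyridin-3-yl in place of 1,2-oxazol-3-yl on a carbonyl carbon. Within the data shown here, no measured step bears directly on this change, since the one available step is unreadable. With all three amides at the limit regardless of the aryl group on the carbonyl carbon, the step of a number no higher from compound 2 to compound 4 (the limit leaves the size open) is expected to be none beyond the scatter, and most likely compound 4 is expected to remain at the limit as well. Compound 4 is therefore estimated at 100000 nM in this assay, within a range from 30000 nM to 200000 nM.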

Compound 4, half-maximal inhibitory concentration: > 100000 nM
Compound 4: only a limit was reported; the forecaster's own chance of this, stated with the estimate: 85%; the middle value lies on the limit itself.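

Compound 4 is also only a limit in this assay, like compound 1 and compound 2, so neither the step from compound 2 to compound 4 nor that from compound 1 to compound 4 can be read. The compounds shown leave open whether any change on the carbonyl carbon alters activity, as the only reading so far is: the limit of > 100000 nM in this assay, at which 4 of the 4 values shown sit.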